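The source may report more compounds than this note shows. Statements on the series, on what has been measured and on what is new or still open speak of the compounds shown alone.

Working notes on the series. The shared core is seen in compound 1 `O=C(/C=C/c1cccc(O)c1)c1cccc(-n2cc(-c3ccccc3)[nH]c2=O)c1`, which in a functional assay on PC-3 cells (Homo sapiens) for inhibition (a lower number here means a stronger inhibitor of growth, a higher number a weaker inhibitor of growth), gives 2820 nM. Compound 2 `O=C(/C=C/c1cccc(O)c1)c1cccc(-n2cc(-c3ccc(Cl)cc3)[nH]c2=O)c1` is a close relative, but in this assay compound 2 stands at "not determined" (no result reported), so no number anchors it. Compound 3 `COc1cc(/C=C/C(=O)c2cccc(-n3cc(-c4ccc(Cl)cc4)[nH]c3=O)c2)ccc1O` differs from compound 2 by 4-hydroxy-3-methoxyphenyl in place of 3-hydroxyphenyl on a double-bonded chain carbon bound to a double-bonded chain carbon. Among the measured compounds shown here, with no measured step between compounds that differ in one place, the size of this change is unknown; a shift of about the scatter, in either direction, seems as likely as none. Compound 3 is expected to give roughly 2500 nM, estimated within 700 nM to 9000 nM.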

Compound 3, concentration for 50% growth inhibition: 1950 nM
Compound 3: the middle estimate sits 1.3-fold (0.11 log units) above what was measured, within the range that was stated.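

Among the compounds shown here, compound 2 has no reported number in this assay, so no step to compound 3 can be read. The compounds shown leave open what replacing 3-hydroxyphenyl with 4-hydroxy-3-methoxyphenyl does to growth inhibition. No supporting evidence bears on this result.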